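Swapping One Dimethylphenyl Group for Another on a Sulfonamide

A few compounds are considered here, and "the series" means these few. Any claim that something is new, unique, unknown or untested is made for them only; others in the source may bear on it.

- compound 1 `Cc1ccc(NS(=O)(=O)c2ccc(N3CCNC3=O)cc2)cc1C` – 230 nM
- compound 2 `Cc1ccc(C)c(NS(=O)(=O)c2ccc(N3CCNC3=O)cc2)c1` – 48 nM

In a functional assay on MCF7 cells (Homo sapiens) for antiproliferative activity, read by sulforhodamine B assay, with a stated time of 48 h (a lower number here means a stronger inhibitor, a higher number a weaker inhibitor), compound 2 has the lower of the two numbers, 48 nM, which makes it the stronger inhibitor so far. Compound 3 `Cc1ccc(NS(=O)(=O)c2ccc(N3CCNC3=O)cc2)c(C)c1` differs from it in one place, on a sulfonamide nitrogen: 2,4-dimethylphenyl in place of 2,5-dimethylphenyl on a sulfonamide nitrogen. Among the measured compounds shown here, the only measured step that bears on this is another swap of dimethylphenyl groups at that place, a 4.8-fold lower number from compound 1 to compound 2 (0.68 log units; beyond the scatter). A step of similar modest size is therefore expected, probably toward a higher number, although one example cannot settle the direction. The estimated value for compound 3 is 110 nM, with a range from 35 nM to 350 nM. This estimate means an expected step of a 2.3-fold higher number from compound 2 to compound 3 (0.36 log units; beyond the scatter).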

Compound 3, half-maximal inhibitory concentration: 230 nM
Compound 3: the middle estimate sits 2.1-fold (0.32 log units) below what was measured, and the stated range covers the measured number.
By their numbers in this assay, from the lowest: compound 2; then compounds 1 and 3 (each within the scatter of the next).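

Only the arrangement of the two methyl groups changes here, yet it matters: 2,4-dimethylphenyl in place of 2,5-dimethylphenyl gives a 4.8-fold higher number from compound 2 to compound 3 (0.68 log units; beyond the scatter), whereas 2,4-dimethylphenyl in place of 3,4-dimethylphenyl gives no change at the digits printed from compound 1 to compound 3 (within the scatter) on the same sulfonamide nitrogen. Among these three isomers, the 2,5-dimethylphenyl group of compound 2 alone stands apart. Nothing available explains this difference. On these data alone, it remains open how 2,6-dimethylphenyl or 3,5-dimethylphenyl would compare. A methoxy group, a chlorine atom or an amine on this ring is also untested among the compounds shown.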